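The compounds below may be only part of what the source reports. "The series", "measured", "known", "first", "only" and "open" are said of these compounds alone.

Measured so far in a functional assay on HEK293 cells for antagonist activity at proteinase-activated receptor 1 (Homo sapiens), read by FLIPR and calcium flux, with a stated time of 15 min; a lower number here means a stronger inhibitor, a higher number a weaker inhibitor:

Compound 1 `C[C@]1(CO)[C@H]2CC[C@](C)(O)[C@@H](/C=C/c3ccc(-c4cccc(F)c4)cn3)[C@]2(C)CC[C@H]1O`: 55000 nM
Compound 2 `C[C@H]1CC[C@@H]2[C@](C)(C=O)[C@H](O)CC[C@@]2(C)[C@@H]1/C=C/c1ccc(-c2cccc(F)c2)cn1`: 1500 nM
Compound 3 `CC(=O)O[C@@H]1CC[C@@]2(C)[C@H](/C=C/c3ccc(-c4cccc(F)c4)cn3)[C@@H](C)CC[C@@H]2C1(C)C`: > 100000 nM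

Of the three, compound 2 gives the lowest number, and compound 1 sits well above it. For compound 3 the assay reports only a limit, > 100000 nM, and no number; compound 3 therefore stands at the weak end of everything shown, as the one value among the three that sits at the limit of > 100000 nM in this assay, at which 1 of the 3 values shown sits.

Compound 4 `CCOC(=O)O[C@@H]1CC[C@@]2(C)[C@H](/C=C/c3ccc(-c4cccc(F)c4)cn3)[C@@H](C)CC[C@@H]2C1(C)C` differs from compound 3 in a single place: ethoxy in place of methyl on a carbonyl carbon. The shared core, the double bond and the fluorophenyl-pyridine arm are kept unchanged, so the whole of the change is the ethoxy in place of methyl on that carbonyl carbon.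

Among the compounds with values here, no pair of measured compounds differs in only one place, so no measured step guides this one. Compound 3 already lies at the limit, and an ester-to-carbonate change of this size gives no ground to expect a return to measurable inhibition. The expected outcome is that compound 4 also remains at or beyond the limit, with no step beyond the scatter, a step that the limit leaves unreadable from compound 3 to compound 4. Compound 4 is estimated at 150000 nM, within 30000 nM to 1000000 nM.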

Compound 4, half-maximal inhibitory concentration: > 100000 nM
Compound 4 was reported as a limit (the forecaster's own chance of this, stated with the estimate: 80%); the middle value is on the limit's open side.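

In this assay compound 4 gives > 100000 nM, which is a limit and not a number. Compound 3 is also reported only as a limit, and no step can be read between compound 3 and compound 4. The compounds shown leave open whether ethoxy in place of methyl on a carbonyl carbon changes inhibition at all.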